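The source may hold more compounds than are shown below. What is called first, only, known or untested is meant among the compounds shown, and "the series" means these compounds.

Compound 1 `O=C(Nc1nnc(-c2ccc(Cl)cc2)s1)c1ccccc1Br`: in a functional assay on the whole organism (integument) for inhibition, with Chilo suppressalis as the target, read by scintillation counting, with a stated time of 72 h (on this read-out lower numbers stand for stronger inhibition and higher numbers for weaker inhibition), compound 1 gives > 5010 nM, a limit of the assay.
Compound 2 `O=C(Nc1nnc(-c2ccc(Cl)cc2)s1)c1ccccc1C(F)(F)F`: in this assay compound 2 gives > 16500 nM, also a limit of the assay.
Compound 3 `Cc1ccccc1C(=O)Nc1nnc(-c2ccc(Cl)cc2)s1`: in this assay compound 3 gives 158 nM.

Going by the values given here, compound 3 thus holds the only number among the three measured compounds; the other two sit at limits. Compound 4 `CCOc1ccccc1C(=O)Nc1nnc(-c2ccc(Cl)cc2)s1` differs from compound 3 by ethoxy in place of methyl on an aromatic carbon. Among the compounds with values here, the steps that bear on this position are an at least 31-fold lower number from compound 1 to compound 3 (1.50 log units; beyond the scatter) and an at least 100-fold lower number from compound 2 to compound 3 (2.01 log units; beyond the scatter), both large, while the step that the two limits leave unreadable from compound 1 to compound 2 cannot be read. Methyl is the only group at this carbon that has given a number, and ethoxy has no precedent here, so the direction is uncertain. For compound 4 a higher number is expected in this assay, a step of a 6.3-fold higher number from compound 3 to compound 4 (0.80 log units; beyond the scatter). Compound 4 is therefore estimated at 1000 nM, with a range from 150 nM to 10000 nM.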

Compound 4, half-maximal inhibitory concentration: > 5010 nM
Compound 4: a limit, no number (the forecaster's own chance of this, stated with the estimate: 35%); middle value at least 5.0-fold (0.69 log units) from the limit.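

In this assay, ethoxy in place of methyl on this aromatic carbon gives an at least 31-fold higher number from compound 3 to compound 4 (1.50 log units; beyond the scatter). Methyl thus remains the only one of the four groups at this carbon to give a number. The steps to compound 4 from compound 1 and from compound 2 join two limits and cannot be read, and compound 4 itself stands at a limit, as compound 1 does: the limit of > 5010 nM in this assay, at which 2 of the 4 values shown sit.

On these data alone, whether methoxy, ethyl or an amine at this carbon would give a number remains open. So does any order among bromo, trifluoromethyl and ethoxy.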